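Isomeric esters in cytotoxicity: compound 1 to compound 3

This account rests on a few compounds, and the source may have more. Where it says the series, first, only, none or still open, it means among the compounds named here.

Working notes on two measured esters and one isomer not yet tested. Compound 1 `CCCCC/C=C\C/C=C\C/C=C\C/C=C\CCCC(=O)OC[C@@H]1C=CC(=O)[C@@H](C2CCCC=C2C)O1` and compound 2 `CCCCCCCC/C=C\CCCCCCCC(=O)OC[C@@H]1C=CC(=O)[C@@H](C2CCCC=C2C)O1` share the same core and differ outside it. In a functional assay on LFCl2A cells (Rattus norvegicus) for cytotoxicity (on this read-out lower numbers stand for stronger inhibition and higher numbers for weaker inhibition), compound 1 gives 5000 nM, while compound 2 gives 35000 nM; compound 1 thus holds the lowest of the two numbers, and its gap to compound 2 lies beyond the scatter. Compound 3 `CCCCC/C=C\C/C=C\C/C=C\C/C=C\CCCC(=O)OC[C@@H]1C=CC(=O)[C@@H](CC2=CCCCC2)O1` has the same atoms as compound 1 joined differently: (cyclohex-1-en-1-yl)methyl in place of 2-methylcyclohex-2-en-1-yl on a saturated ring carbon. Going by the values given here, no step of this kind has been measured, so the two values above are all that frames the expectation. The change is expected to cost little or nothing, and the step in this assay is estimated at a 1.4-fold higher number from compound 1 to compound 3 (0.15 log units; within the scatter), a small rise that would not clearly exceed the scatter. Compound 3 is therefore expected to give about 7000 nM, within 2000 nM to 25000 nM.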

Compound 3, half-maximal inhibitory concentration: 35000 nM
Estimate against measurement, compound 3: 5.0-fold (0.70 log units) below, and the stated range ends below it.
By their numbers in this assay, from the lowest: compound 1; then compounds 2 and 3 (each within the scatter of the next).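

Going by these compounds alone, this is the first step read at this position: in this assay, (cyclohex-1-en-1-yl)methyl in place of 2-methylcyclohex-2-en-1-yl on a saturated ring carbon gives a 7.0-fold higher number from compound 1 to compound 3 (0.85 log units; beyond the scatter). Both groups have one six-membered non-aromatic ring of carbon only and 1 double bond outside aromatic rings, so the read-out at this place, next to the ring oxygen, changes with how the same atoms are joined and not only with which atoms are present. Nothing at hand bears on why this step arises.

Going by these compounds, whether the same change carries the same step on the ester chain of compound 2 stays open. Also open, on these data alone, is what a cyclohexyl group without a double bond, or an aminomethyl group, would give at this position.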